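Swapping a nitrophenyl for a dimethoxyphenyl at the chain end

The source may report more compounds than this note shows. Statements on the series, on what has been measured and on what is new or still open speak of the compounds shown alone.

Within the data shown here, compound 3 `CC(CC[C@H]1/C(=C/c2ccc([N+](=O)[O-])cc2)CC[C@H]2C(C)(C)CCC[C@]12C)CC(=O)O` gives 169000 nM in a functional assay on K562 cells (Homo sapiens) for cytotoxicity, read by MTT assay, with a stated time of 72 h (a lower number here means a stronger inhibitor, a higher number a weaker inhibitor), the only number in the set. Compound 1 `COc1ccc(/C=C2\CC[C@H]3C(C)(C)CCC[C@]3(C)[C@H]2CCC(C)CC(=O)O)cc1` reaches only the limit > 200000 nM in this assay. Compound 2 `Cc1ccc(/C=C2\CC[C@H]3C(C)(C)CCC[C@]3(C)[C@H]2CCC(C)CC(=O)O)cc1` likewise stops at the limit > 200000 nM. Compound 4 `COc1ccc(/C=C2\CC[C@H]3C(C)(C)CCC[C@]3(C)[C@H]2CCC(C)CC(=O)O)cc1OC` differs from compound 3 by 3,4-dimethoxyphenyl in place of 4-nitrophenyl on a double-bonded chain carbon bound to a double-bonded ring carbon. The steps of an at least 1.1-fold lower number from compound 1 to compound 3 (0.07 log units; that floor lies within the scatter) and an at least 1.1-fold lower number from compound 2 to compound 3 (0.07 log units; that floor lies within the scatter) bear on this change, both floors lying within the scatter, and a step that the two limits leave unreadable from compound 1 to compound 2 cannot be read; the limit of > 200000 nM in this assay, at which 2 of the 3 values shown sit, marks the ceiling of what was seen. Given the limit reached by the methoxy-bearing compound 1, compound 4 is expected to move by a 1.5-fold higher number from compound 3 to compound 4 (0.17 log units; within the scatter), ending at or past that limit. Compound 4 is estimated at 250000 nM, between 120000 nM and 600000 nM.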

Compound 4, half-maximal inhibitory concentration: > 200000 nM
Compound 4: no number, only a limit; the forecaster's own chance of this, stated with the estimate: 70%; the middle value does not contradict the limit.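

In this assay compound 4 gives only a limit, > 200000 nM, so a second methoxy on the aromatic ring brings no readable number. Putting 3,4-dimethoxyphenyl in place of 4-nitrophenyl gives an at least 1.1-fold higher number from compound 3 to compound 4 (0.07 log units; that floor lies within the scatter). The steps from compound 1 and from compound 2 to compound 4 cannot be read, and the ceiling now holds most of the set: the limit of > 200000 nM in this assay, at which 3 of the 4 values shown sit.

Among these compounds, compound 3 still holds the only number. Going by these compounds, whether an amino group on the aromatic ring, or a methyl ester in place of the carboxylic acid, would give a clearly lower number stays open.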